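Thiourea-linked analogues of a shared core in one cell assay

The source may report more compounds than this note shows. Statements on the series, on what has been measured and on what is new or still open speak of the compounds shown alone.

Compound 1 `NC(=O)c1c(NC(=O)c2ccccc2Cl)sc2c1CCN(Cc1ccc(Cl)cc1Cl)C2`: 16300 nM
Compound 2 `NC(=O)c1c(NC(=O)c2cccc([N+](=O)[O-])c2)sc2c1CCN(Cc1c(Cl)cccc1Cl)C2`: 13500 nM
Compound 3 `NC(=O)c1c(NC(=O)c2ccccc2Cl)sc2c1CCN(C(=S)Nc1cccc3ccccc13)C2`: 20700 nM

In a functional assay on MKN-74 cells (Homo sapiens) for antiproliferative activity, with a stated time of 24 h (a lower number here means a stronger inhibitor, a higher number a weaker inhibitor), compound 3 gives 20700 nM. That number lies within the usual scatter of the values of compound 1 and compound 2, so the three compounds cannot be told apart on these data, and all of them count as weak inhibitors in this assay.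

Compound 4 `NC(=O)c1c(NC(=O)c2ccccc2Cl)sc2c1CCN(C(=S)Nc1ccc(C(F)(F)F)cc1)C2` differs from compound 3 in one place: 4-(trifluoromethyl)phenyl in place of naphthalen-1-yl on an amide-type nitrogen. Among the compounds with values here, no comparable step between measured compounds exists here, so nothing in the data points to a change in either direction. Compound 4 is therefore expected to stay close to compound 3, with a step of a 1.2-fold lower number from compound 3 to compound 4 (0.06 log units; within the scatter) that is expected to fall inside the scatter. For compound 4 the estimate is 18000 nM, with a range from 7000 nM to 45000 nM.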

Compound 4, half-maximal inhibitory concentration: 7090 nM
Beside the measured number, compound 4's estimate is 2.5-fold (0.40 log units) above it; the range from low to high includes it.
By their numbers in this assay, from the lowest: compounds 4, 2, 1 and 3 (each within the scatter of the next, the first and the last beyond it).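

In this assay, within the data shown here, the aromatic group on the amide-type nitrogen is the first place where a single change gives a readable difference: a 2.9-fold lower number from compound 3 to compound 4 (0.47 log units; beyond the scatter), a modest step beyond the scatter. The group that enters has the same heavy-atom count as the one that leaves, but it has one aromatic ring instead of two and brings in fluorine. No measurement shown here accounts for the step.

Going by these compounds, whether the loss of a ring or the arrival of trifluoromethyl goes with the lower number remains open. So does the outcome with an unsubstituted phenyl, a methoxy group or an amine at this place.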